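The source may report more compounds than this note shows. Statements on the series, on what has been measured and on what is new or still open speak of the compounds shown alone.

Compound 3 `Nc1ccc(/C=C2\SC(=O)N(Cc3cccc(Cl)c3)C2=O)cc1` gives 18000 nM in a functional assay on CCRF-CEM cells (Homo sapiens) for cytotoxicity, read by cell counting, with a stated time of 3 days (on this read-out higher numbers stand for weaker inhibition and lower numbers for stronger inhibition), the lowest of the three numbers shown. Compound 2 `Nc1ccc(/C=C2\SC(=O)N(Cc3ccccc3)C2=O)cc1` gives 42000 nM, and compound 1 `Nc1ccc(/C=C2\SC(=O)N(Cc3ccc(Cl)cc3)C2=O)cc1` gives 87000 nM. Compound 4 `Cc1ccc(CN2C(=O)S/C(=C\c3ccc(N)cc3)C2=O)cc1` differs from compound 3 by 4-methylphenyl in place of 3-chlorophenyl on a saturated chain carbon bound to an amide-type nitrogen in a ring. For the measured compounds named here, two measured steps bear on this: moving the chloro substituent gave a 4.8-fold lower number from compound 1 to compound 3 (0.68 log units; beyond the scatter), and adding it gave a 2.3-fold lower number from compound 2 to compound 3 (0.37 log units; beyond the scatter). Compound 4 carries its substituent at the position that in compound 1 gave the weakest result, so a return toward weaker inhibition is expected, roughly a 2.8-fold higher number from compound 3 to compound 4 (0.44 log units; beyond the scatter). Compound 4 is therefore estimated at 50000 nM, within a range from 15000 nM to 150000 nM.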

Compound 4, half-maximal inhibitory concentration: > 250000 nM
Compound 4 gave a limit, no number; the forecaster's own chance of this, stated with the estimate: 10%; at least 5.0-fold (0.69 log units) between middle value and limit.
By their numbers in this assay, from the lowest: compound 3; then compound 2; then compound 1. At a limit, above all of these: compound 4.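

In this assay compound 4 gives > 250000 nM, which is a limit of the assay and not a number. Exchanging the aromatic group on this chain carbon gave an at least 13-fold higher number from compound 3 to compound 4 (1.14 log units; beyond the scatter), far larger than any earlier step, while methyl in place of hydrogen gave an at least 5.9-fold higher number from compound 2 to compound 4 (0.77 log units; beyond the scatter), and methyl in place of chloro gave an at least 2.8-fold higher number from compound 1 to compound 4 (0.45 log units; beyond the scatter). So methyl and chloro are not interchangeable here, and one small change at this place can move the number a long way. Still open, from the compounds shown here alone, is how a methoxy group or an amine on this aromatic ring would read. Also open, going by these compounds, is whether methyl, placed where compound 3 carries its chloro, would keep that lower number.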